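The compounds below may be only part of what the source reports. "The series", "measured", "known", "first", "only" and "open" are said of these compounds alone.

Of the compounds shown here, three with one shared core have been measured in an assay on T-REx-293 cells for inhibition of potassium channel subfamily T member 1 (Homo sapiens), read by patch clamp; a higher number here means a weaker inhibitor, a lower number a stronger inhibitor. Compound 1 `Cc1cccc(-c2noc(C(C)NC(=O)c3cc(C4CC4)nn3C)n2)c1` gives 1880 nM; compound 2 `Cc1cccc(-c2noc([C@H](C)NC(=O)c3cc(C4CC4)nn3C)n2)c1`, which has its stereocentre drawn in one configuration, gives 167 nM. Among the measured compounds shown here, the step of an 11-fold lower number from compound 1 to compound 2 (1.05 log units; beyond the scatter) is the only single change measured here, and it may simply reflect that (the fact that one of compounds 1 and 2 is drawn with a defined configuration and the other without, at the place where they differ). Compound 3 `Cc1ccnc(-c2noc([C@H](C)NC(=O)c3cc(C(F)(F)F)nn3C)n2)c1` gives 4470 nM, the highest of the three numbers, so it is the weakest inhibitor in this set.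

Compound 4 `CO[C@@H](C)c1cc(-c2noc([C@H](C)NC(=O)c3cc(C(F)(F)F)nn3C)n2)ccn1` is not yet measured. It differs from compound 3 in this way: a group of 10 heavy atoms (8 carbon, 1 nitrogen, 1 oxygen; one six-membered aromatic ring with 1 hetero atom) in place of a group of 7 heavy atoms (6 carbon, 1 nitrogen; one six-membered aromatic ring with 1 hetero atom), on an aromatic carbon. For the measured compounds named here, no measured step touches this position, so the only measured step, the stereochemical one, gives no guide to the size or direction of this change. With nothing to point either way, the expected step of a 1.5-fold lower number from compound 3 to compound 4 (0.17 log units; within the scatter) is one that stays close to compound 3, with a wide allowance for error. Compound 4 is therefore expected to give about 3000 nM in this assay, somewhere between 800 nM and 12000 nM.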

Compound 4, half-maximal inhibitory concentration: 744 nM
Compound 4: the middle estimate sits 4.0-fold (0.61 log units) above what was measured; the whole stated range lies above it.
By their numbers in this assay, from the lowest: compound 2; then compound 4; then compound 1; then compound 3.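

Among the compounds shown here, this is the first measured change at this aromatic carbon of the five-membered ring, and it matters: putting the larger group of compound 4 in place of 4-methylpyridin-2-yl gives a 6.0-fold lower number from compound 3 to compound 4 (0.78 log units; beyond the scatter). The position therefore tolerates a larger group with an added oxygen and a defined stereocentre, and inhibition gets stronger rather than being lost. No measured information here bears on why the number falls.

The compounds shown do not separate the contributions of the oxygen, the added carbons and the stereocentre of the entering group, nor show how its opposite configuration would compare. They also leave open how a simple methoxy group, an amine or a longer alkyl chain would behave here, and whether the same swap would help in compounds with cyclopropyl on the shared core.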